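Taking the Chloro Group off Compound 1

The source may report more compounds than this note shows. Statements on the series, on what has been measured and on what is new or still open speak of the compounds shown alone.

Compound 1 `N#Cc1c(N)sc(C(=O)Nc2ccc(Cl)cc2)c1-c1ccccc1`: 650 nM
Compound 2 `N#CCC(=O)Nc1sc(C(=O)Nc2ccc(Cl)cc2)c(-c2ccccc2)c1C#N`: 860 nM

For the measured compounds named here, only two compounds have been measured so far. In a functional assay on HT-29 cells (Homo sapiens) for inhibition, read by MTT assay (a lower number here means a stronger inhibitor, a higher number a weaker inhibitor), compound 1 gives 650 nM, and compound 2 gives 860 nM. Going by the values given here, compound 1 therefore stands level with its only measured neighbour. The step between them is a 1.3-fold higher number from compound 1 to compound 2 (0.12 log units; within the scatter), and it places (cyanomethyl)carbonyl in place of hydrogen on a nitrogen on an aromatic ring.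

Compound 3 `N#Cc1c(N)sc(C(=O)Nc2ccccc2)c1-c1ccccc1` has not been measured yet. Its difference from compound 1 is hydrogen in place of chloro on an aromatic carbon. Put simply, it has hydrogen in place of chloro on an aromatic carbon, so 4-chlorophenyl becomes phenyl.

Among the compounds with values here, the one measured step lies at a different place on the molecule, so it bears on this change only loosely. Within the data shown here, no measured pair shows what losing the chloro group does. A step beyond the scatter is therefore not expected with any confidence, though a slight lean toward a higher number seems reasonable. The expected change is a 1.4-fold higher number from compound 1 to compound 3 (0.14 log units; within the scatter). For compound 3 the estimated value is 900 nM, with an expected range from 300 nM to 2700 nM.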

Compound 3, half-maximal inhibitory concentration: 8390 nM
Compound 3: the middle estimate sits 9.3-fold (0.97 log units) below what was measured; measured number above the stated range.
By their numbers in this assay, from the lowest: compounds 1 and 2 (each within the scatter of the next); then compound 3.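

In this assay the single chlorine atom proves to matter a great deal, since going from 4-chlorophenyl to phenyl gives a 13-fold higher number from compound 1 to compound 3 (1.11 log units; beyond the scatter) and so leaves a clearly weaker inhibitor. For the compounds shown here, this is the first measured change on this scaffold to move the number beyond the scatter, as the step at the other end of the molecule, on the ring nitrogen, did not (a 1.3-fold higher number from compound 1 to compound 2 (0.12 log units; within the scatter)). The place para to a large group on this six-membered aromatic ring is therefore sensitive, and on the core of compound 1 the 4-chlorophenyl group is clearly preferred to phenyl, although no supporting measurement bears on what lies behind this step.

The compounds shown leave open whether chlorine itself is needed or whether a fluoro, bromo, methyl or methoxy group on the same carbon would keep the number near that of compound 1 rather than that of compound 3. They also leave open whether taking the chloro group off compound 2, with its (cyanomethyl)carbonyl group, would have an effect of the same size.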